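The source may report more compounds than this note shows. Statements on the series, on what has been measured and on what is new or still open speak of the compounds shown alone.

Measured in a functional assay on A-375 cells (Homo sapiens) for cytotoxicity, read by MTT assay, with a stated time of 72 h; a higher number here means a weaker inhibitor, a lower number a stronger inhibitor:
- compound 1 `CN(C)CCCCCn1c2c(c3ccccc31)C(=O)c1c[n+]([O-])c3ccccc3c1C2=O`: 560 nM
- compound 2 `CN1CCN(CCCCn2c3c(c4ccccc42)C(=O)c2c[n+]([O-])c4ccccc4c2C3=O)CC1`: 30 nM
- compound 3 `O=C1c2c[n+]([O-])c3ccccc3c2C(=O)c2c1c1ccccc1n2CCN1CCCC1`: 430 nM

In this assay, compound 3 sits at the upper end of this small set. Its nearest neighbour gives a 1.3-fold lower number from compound 1 to compound 3 (0.11 log units; within the scatter), which lies within the scatter, so those two values cannot be ordered. The furthest gives a 14-fold higher number from compound 2 to compound 3 (1.16 log units; beyond the scatter).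

The next compound is compound 4 `CCCCN1CCN(CCCCn2c3c(c4ccccc42)C(=O)c2c[n+]([O-])c4ccccc4c2C3=O)CC1`, and the change is 2-(4-butylpiperazin-1-yl)ethyl in place of pyrrolidin-1-yl on a saturated chain carbon, two bonds along the chain from an aromatic nitrogen. The closest measured precedent is a 14-fold higher number from compound 2 to compound 3 (1.16 log units; beyond the scatter), which is the same kind of exchange read in reverse, with 2-(4-methylpiperazin-1-yl)ethyl as the group that leaves. The step of a 19-fold lower number from compound 1 to compound 2 (1.27 log units; beyond the scatter) also reaches the low value of compound 2 with a methylpiperazine. Going by the values given here, no measured step shows what butyl does in place of methyl on the piperazine, so the precedent carries over only in part.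

A large step toward a lower number is therefore expected, estimated as an 8.6-fold lower number from compound 3 to compound 4 (0.93 log units; beyond the scatter). For compound 4 the estimated value is 50 nM, with an expected range of 15 nM to 200 nM.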

Compound 4, half-maximal inhibitory concentration: 2150 nM
The estimate for compound 4 lay 43-fold (1.63 log units) below the measured number; the whole stated range lies below it.
By their numbers in this assay, from the lowest: compound 2; then compounds 3 and 1 (each within the scatter of the next); then compound 4.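

In this assay, the size of the group on the piperazine proves decisive, as propyl in place of hydrogen on a saturated chain carbon bound to an amine nitrogen in a ring gives a large loss (a 72-fold higher number from compound 2 to compound 4 (1.86 log units; beyond the scatter)). The low number of compound 2 therefore does not extend to the piperazine in general. With butyl on the piperazine, the exchange for pyrrolidin-1-yl runs the opposite way to the earlier methylpiperazine precedent (a 5.0-fold higher number from compound 3 to compound 4 (0.70 log units; beyond the scatter)), and 4-butylpiperazin-1-yl in place of (dimethylamino)methyl also raises the number (a 3.8-fold higher number from compound 1 to compound 4 (0.58 log units; beyond the scatter)).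

Nothing available accounts for this result. Still open, going by these compounds, is how the number moves between methyl and butyl on the piperazine, for instance with ethyl or propyl there, and how a hydroxyethyl group would compare.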